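Methoxy Added to the Core of Compound 3

This account rests on a few compounds, and the source may have more. Where it says the series, first, only, none or still open, it means among the compounds named here.

Three related compounds have so far been tested in a functional assay on A549 cells (Homo sapiens) for cytotoxicity, read by sulforhodamine B assay, with a stated time of 48 h; on this read-out lower numbers stand for stronger inhibition and higher numbers for weaker inhibition. Compound 1 `COc1ccc2c(c1)c(C=O)cn2Cc1cn([C@@H]2O[C@H](COC(C)=O)[C@@H](OC(C)=O)[C@H](OC(C)=O)[C@H]2OC(C)=O)nn1` gives 106000 nM. Compound 2 `COc1ccc2c(c1)c(/C=N/O)cn2Cc1cn([C@@H]2O[C@H](COC(C)=O)[C@@H](OC(C)=O)[C@H](OC(C)=O)[C@H]2OC(C)=O)nn1` reaches only the limit of this assay, > 200000 nM. Among the compounds with values here, the one measured step between compounds that differ in a single place is an at least 1.8-fold higher number from compound 1 to compound 2 (0.27 log units; that floor lies within the scatter); since compound 2 sits at a limit (the limit of > 200000 nM in this assay, at which 1 of the 3 values shown sits), only a floor for that step is known. Compound 3 `CC(=O)OC[C@H]1O[C@@H](n2cc(Cn3cc(/C=C4/C(=O)Nc5ccc(F)cc54)c4ccccc43)nn2)[C@H](OC(C)=O)[C@@H](OC(C)=O)[C@@H]1OC(C)=O` gives 36900 nM, the lower of the two numbers available; the nearest number belongs to compound 1 and lies beyond the scatter above it.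

Compound 4 `COc1ccc2c(c1)c(/C=C1/C(=O)Nc3ccc(F)cc31)cn2Cc1cn([C@@H]2O[C@H](COC(C)=O)[C@@H](OC(C)=O)[C@H](OC(C)=O)[C@H]2OC(C)=O)nn1` differs from compound 3 by methoxy in place of hydrogen on an aromatic carbon. Compounds 1 and 2 both carry this methoxy group while compound 3 does not, yet each of them also differs from compound 3 in another part of the molecule, so none of the shown values isolates the methoxy on its own. The step from compound 1 to compound 2 concerns a different position and does not bear on it. Within the data shown here, with no measured step to anchor it, a shift within the scatter is expected, as a 1.1-fold lower number from compound 3 to compound 4 (0.05 log units; within the scatter). Compound 4 is therefore estimated at 33000 nM, with a range from 12000 nM to 90000 nM.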

Compound 4, half-maximal inhibitory concentration: > 200000 nM
Compound 4: no number, only a limit; the forecaster's own chance of this, stated with the estimate: 5%; at least 6.0-fold (0.78 log units) between middle value and limit.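

The methoxy group gets its first isolated test here: placed on an aromatic carbon, meta to one fused ring and para to another, in place of hydrogen, it gives an at least 5.4-fold higher number from compound 3 to compound 4 (0.73 log units; beyond the scatter). Adding this one group to compound 3 therefore weakens the result in this assay by a margin beyond the scatter, something compounds 1 and 2 could not show, as each differs from compound 3 in more than one place. Among the methoxy-bearing compounds, the group of 12 heavy atoms in place of the group of 2 heavy atoms gives an at least 1.8-fold higher number from compound 1 to compound 4 (0.27 log units; that floor lies within the scatter), a floor within the scatter, so this larger group shows no gain when methoxy is present, and the step between compound 2 and compound 4 cannot be read, since neither value is a number: the limit of > 200000 nM in this assay, at which 2 of the 4 values shown sit.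

As far as these compounds go, how much weaker compound 4 really is stays open, as its value is only a limit. The compounds shown also leave open whether a smaller group at this place, such as methyl, fluorine or hydroxyl, would keep the value of compound 3 or lose it as methoxy does.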